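The source may hold more compounds than are shown below. What is called first, only, known or untested is meant among the compounds shown, and "the series" means these compounds.

Measured so far:
Compound 1 `CSc1nnc(COc2cc(C)c3c(C)cc(=O)oc3c2)o1` gives > 100000 nM in a functional assay on MCF7 cells (Homo sapiens) for antiproliferative activity, read by MTT assay, with a stated time of 24 h (on this read-out lower numbers stand for stronger inhibition and higher numbers for weaker inhibition), a limit of the assay rather than a number.
Compound 2 `CCSc1nnc(COc2cc(C)c3c(C)cc(=O)oc3c2)o1` gives > 100000 nM in this assay, again only a limit.
Compound 3 `CCCCSc1nnc(COc2cc(C)c3c(C)cc(=O)oc3c2)o1` gives > 100000 nM in this assay, likewise a limit.

Compound 2 therefore stands nowhere that can be placed on a scale: its result is a limit, and the same holds for its two neighbours, so that (the limit of > 100000 nM in this assay, at which 3 of the 3 values shown sit). The steps among them, a step that the two limits leave unreadable from compound 1 to compound 2, a step that the two limits leave unreadable from compound 1 to compound 3 and a step that the two limits leave unreadable from compound 2 to compound 3, are all unreadable for the same reason, and they tell nothing about whether lengthening the chain on the sulfur helps or hurts.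

Compound 4 `Cc1cc(OCc2nnc(SCc3ccc(F)c(F)c3)o2)cc2oc(=O)cc(C)c12` differs from compound 2 by 3,4-difluorophenyl in place of methyl on a saturated chain carbon bound to a sulfur. For the measured compounds named here, no measured step resembles this change, since the only steps available swap one small chain for another and all end at the limit. The expectation for compound 4 in this assay therefore rests on no measured direction, and the most likely outcome is another limit, with a modest chance that the larger group brings a readable number. Compound 4 is estimated at 90000 nM, within 20000 nM to 400000 nM. This estimate means a step of an at least 1.1-fold lower number from compound 2 to compound 4 (0.04 log units; that floor lies within the scatter), which is expected to lie within the scatter or to remain unreadable.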

Compound 4, half-maximal inhibitory concentration: 33300 nM
For compound 4 the middle estimate is 2.7-fold (0.43 log units) above the measured one, and the stated range covers the measured number.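

The steps among compound 1, compound 2 and compound 3 cannot be read, and all three results are a limit of the assay rather than a number: the limit of > 100000 nM in this assay, at which 3 of the 4 values shown sit. For the compounds shown here, compound 4 gives the first readable value at this position, with 3,4-difluorophenyl on the saturated chain carbon bound to a sulfur, and the printed steps are an at least 3.0-fold lower number from compound 2 to compound 4 (0.47 log units; beyond the scatter), an at least 3.0-fold lower number from compound 3 to compound 4 (0.47 log units; beyond the scatter) and an at least 3.0-fold lower number from compound 1 to compound 4 (0.47 log units; beyond the scatter). Changing the group at this position can therefore move the result beyond the usual scatter, which the small chains alone never showed.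

From the compounds shown here alone, whether the ring or its two fluorines matter remains open, and a plain benzyl group on the sulfur would help separate the two. Also open, going by these compounds, is how an amine or a carboxylic acid at the end of the chain on the sulfur would read.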